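A few compounds are considered here, and "the series" means these few. Any claim that something is new, unique, unknown or untested is made for them only; others in the source may bear on it.

Working notes on the series, sulfonamide acidity.

Compound 1 `O=S(=O)(Nc1ccccc1)c1ccccc1` is the parent of the set. Within the data shown here, in an ADME assay, compound 1 gives 9.1, the highest of the two numbers so far. Among the measured compounds shown here, its nearest neighbour is compound 2 `O=S(=O)(Nc1ccccc1)c1ccc(Cl)cc1`, which in this assay gives 8.47; the single step, chloro in place of hydrogen on an aromatic carbon, is a number 0.63 log units lower from compound 1 to compound 2 (beyond the scatter).

The step to compound 3 `Cc1ccc(NS(=O)(=O)c2ccccc2)cc1` is a different one: methyl in place of hydrogen on an aromatic carbon, para to a large group. For the measured compounds named here, no measured step in this set involves a methyl, and the only step at hand is the chloro one, which moved the number downward by a modest amount. The methyl step is not comparable to it, and no direction can be drawn from the data. A step of a number 0.20 log units higher from compound 1 to compound 3 (within the scatter) is expected, within or close to the scatter. Compound 3 is therefore estimated at 9.3, in the range 8.9 to 9.7.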

Compound 3, acid dissociation constant: 9.34
Estimate against measurement, compound 3: 0.04 log units below, within the range that was stated.
By their numbers in this assay, from the lowest: compound 2; then compounds 1 and 3 (each within the scatter of the next).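

In this assay, methyl in place of hydrogen on an aromatic carbon, para to a large group, gives a number 0.24 log units higher from compound 1 to compound 3 (within the scatter) and so cannot be told apart from no change at this position. Among these compounds, this is the first step that stays inside the scatter, whereas the chloro step, a number 0.63 log units lower from compound 1 to compound 2 (beyond the scatter), lay beyond it. No measurement at hand gives a reason for the size of either step.

The compounds shown leave open whether an amine, a methoxy group or a carboxylic acid in place of this methyl would move the number beyond the scatter. Among the compounds shown here, they also leave open whether chloro in place of this methyl would give a step like the one seen with compound 2.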